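This account rests on a few compounds, and the source may have more. Where it says the series, first, only, none or still open, it means among the compounds named here.

Compound 1 `O=C1Oc2ccccc2N/C1=C\C(=O)c1ccncc1`, compound 2 `Cc1ccccc1C(=O)/C=C1\Nc2ccccc2OC1=O` and compound 3 `O=C1Oc2ccccc2N/C1=C\C(=O)c1cccc(Cl)c1` share one core and differ only in the aryl group on the carbonyl carbon. In an ADME assay on Vero cells (Chlorocebus sabaeus) for cytotoxicity, read by MTT assay, with a stated time of 72 h (a higher number here means that more compound is tolerated, a lower number that less compound is tolerated), compound 1 gives > 1870000 nM, which is a limit of the assay. Compound 2 gives > 1790000 nM in this assay, again a limit. Among the compounds with values here, compound 3 gives 1610000 nM in this assay, the only plain number among the values shown. The step of an at least 1.1-fold lower number from compound 1 to compound 3 (0.06 log units; that floor lies within the scatter) and the step of an at least 1.1-fold lower number from compound 2 to compound 3 (0.04 log units; that floor lies within the scatter) both have floors within the scatter, and the step that the two limits leave unreadable from compound 1 to compound 2 cannot be read, since both values sit at limits, the limit of > 1790000 nM in this assay, at which 1 of the 3 values shown sits, and (the limit of > 1870000 nM in this assay, at which 1 of the 3 values shown sits).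

Compound 4 `O=C1Oc2ccccc2N/C1=C\C(=O)c1ccccc1Cl` is the untested partner of compound 3: 2-chlorophenyl in place of 3-chlorophenyl on a carbonyl carbon. Every measured step exchanges one aryl group for another and none is shown to exceed the scatter, so the expected step in this assay is a 1.0-fold lower number from compound 3 to compound 4 (0.00 log units; within the scatter), nothing beyond the scatter. Compound 4 is therefore expected to give about 1600000 nM in this assay. The expected range for compound 4 runs from 800000 nM to 3200000 nM.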

Compound 4, half-maximal cytotoxic concentration: 1570000 nM
The estimate for compound 4 lay 1.0-fold (0.01 log units) above the measured number, and the stated range covers the measured number.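

Within the data shown here, with 2-chlorophenyl in place of 3-chlorophenyl on a carbonyl carbon, this assay gives a 1.0-fold lower number from compound 3 to compound 4 (0.01 log units; within the scatter), the only step here between two plain numbers, so at this place the change of chlorine position on the ring shows no difference beyond the scatter. Chloro in place of methyl gives an at least 1.1-fold lower number from compound 2 to compound 4 (0.05 log units; that floor lies within the scatter), which stays a floor because compound 2 sits at a limit: the limit of > 1790000 nM in this assay, at which 1 of the 4 values shown sits. Likewise, 2-chlorophenyl in place of pyridin-4-yl gives an at least 1.1-fold lower number from compound 1 to compound 4 (0.07 log units; that floor lies within the scatter), which stays a floor because compound 1 sits at a limit: the limit of > 1870000 nM in this assay, at which 1 of the 4 values shown sits.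

The compounds shown leave open how far the values of compound 1 and compound 2 really lie from those of the chlorophenyl compounds. They also leave open whether an amine or a carboxylic acid on this aryl ring would give a step beyond the scatter in this assay.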